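The compounds below may be only part of what the source reports. "The series", "measured", "known", "first", "only" and "open" are said of these compounds alone.

Compound 3 `CCn1cc(-c2nc3ccc([N+](=O)[O-])cc3[nH]2)c(=O)c2cc(F)c(N3CCNCC3)cc21` gives 1100 nM in a functional assay on KB cells (Homo sapiens) for cytotoxicity, read by MTT assay, with a stated time of 48 h (a lower number here means a stronger inhibitor, a higher number a weaker inhibitor), the lowest of the three numbers, though a 1.5-fold lower number from compound 2 to compound 3 (0.16 log units; within the scatter). Compound 2 `CCn1cc(-c2nc3ccc(Cl)cc3[nH]2)c(=O)c2cc(F)c(N3CCNCC3)cc21` gives 1600 nM, and compound 1 `CCn1cc(-c2nc3ccccc3[nH]2)c(=O)c2cc(F)c(N3CCNCC3)cc21` gives 10500 nM. Compound 4 `CCn1cc(-c2nc3ccc(N)cc3[nH]2)c(=O)c2cc(F)c(N3CCNCC3)cc21` differs from compound 3 by amino in place of nitro on an aromatic carbon. Within the data shown here, the steps that bear on this change are a 6.6-fold lower number from compound 1 to compound 2 (0.82 log units; beyond the scatter) and a 9.5-fold lower number from compound 1 to compound 3 (0.98 log units; beyond the scatter): each substituent on this aromatic carbon gave a modest gain over hydrogen, but no measured step shows amino there. A modest rise relative to compound 3 is therefore expected, stopping short of the number of compound 1. Compound 4 is estimated at 3500 nM, between 900 nM and 13000 nM, which would mean a 3.2-fold higher number from compound 3 to compound 4 (0.50 log units; beyond the scatter).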

Compound 4, half-maximal inhibitory concentration: 35400 nM
For compound 4 the middle estimate is 10-fold (1.00 log units) below the measured one; the measured number lies above the stated range.
By their numbers in this assay, from the lowest: compounds 3 and 2 (each within the scatter of the next); then compound 1; then compound 4.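

In this assay, among these compounds, amino is the first group at this aromatic carbon to raise the number over hydrogen (a 3.4-fold higher number from compound 1 to compound 4 (0.53 log units; beyond the scatter)), whereas chloro and nitro had both lowered it. Replacing those groups with amino therefore gives large steps, both with nitro (a 32-fold higher number from compound 3 to compound 4 (1.51 log units; beyond the scatter)) and with chloro (a 22-fold higher number from compound 2 to compound 4 (1.34 log units; beyond the scatter)), so a substituent here does not by itself lower the number. No measurement shown accounts for this reversal. Going by these compounds, whether a methoxy group, a carboxylic acid or an acetamide at this carbon would behave like amino or like chloro and nitro remains open.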